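Ester aryl substituent and antiproliferative inhibition in the series

The source may hold more compounds than are shown below. What is called first, only, known or untested is meant among the compounds shown, and "the series" means these compounds.

Compound 1 `COc1cccc(C(=O)Oc2cc3c(cc2C)[C@@H](C(C)C)CC=C3C)c1` gives 16.3% in a functional assay on PC-3 cells (Homo sapiens) for antiproliferative activity, read by sulforhodamine B assay, with a stated time of 48 h, tested at 50 uM (on this read-out lower numbers stand for less inhibition and higher numbers for more inhibition at the one concentration tested (going by the name of the read-out)), the lowest of the three numbers measured. Compound 2 `CC1=CC[C@H](C(C)C)c2cc(C)c(OC(=O)c3ccc(C)cc3)cc21` gives 49.6% and compound 3 `CC1=CC[C@H](C(C)C)c2cc(C)c(OC(=O)c3ccc(Cl)cc3)cc21` gives 34.1%. Both measured steps away from compound 1 raise inhibition: a number 33.3 percentage points higher from compound 1 to compound 2 (beyond the scatter) and a number 17.8 percentage points higher from compound 1 to compound 3 (beyond the scatter), while a number 15.5 percentage points lower from compound 2 to compound 3 (beyond the scatter). Compound 4 `CC1=CC[C@H](C(C)C)c2cc(C)c(OC(=O)c3cccc(C(F)(F)F)c3)cc21` differs from compound 1 by trifluoromethyl in place of methoxy on an aromatic carbon, on an aromatic carbon of a six-membered aromatic ring of carbon only. Going by the values given here, no measured step exchanges methoxy for trifluoromethyl, so the bearing of the steps from compound 1 to compound 2 and to compound 3 is indirect; they show only that replacing the methoxy-bearing aryl group has raised inhibition. A modest increase is therefore expected, a number 13.7 percentage points higher from compound 1 to compound 4 (beyond the scatter). Compound 4 is estimated at 30%, within 14% to 48%.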

Compound 4, a percentage reported as inhibition, at one concentration (the size of the read-out at that concentration, not a potency): 25.4%
The estimate for compound 4 lay 4.6 percentage points above the measured number; measured number inside the range.
By their numbers in this assay, from the lowest: compounds 1, 4 and 3 (each within the scatter of the next, the first and the last beyond it); then compound 2.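

In this assay, trifluoromethyl in place of methoxy, meta to a large group, gives a number 9.1 percentage points higher from compound 1 to compound 4 (within the scatter). The earlier steps shown here from compound 1 exchanged the whole substituted aryl group, whereas this one changes only the group at this place, and the change stays within the scatter. Nothing on hand accounts for this result.

Open, as far as these compounds go, is whether an amine or a carboxylic acid at this place would give a step beyond the scatter. Also open, from the compounds shown here alone, is how methyl or chloro would read here.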